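The source may report more compounds than this note shows. Statements on the series, on what has been measured and on what is new or still open speak of the compounds shown alone.

Values in an ADME assay on Vero cells (Chlorocebus sabaeus) for cytotoxicity, read by MTT assay; a higher number here means that more compound is tolerated, a lower number that less compound is tolerated:
Compound 1 `Cn1nc(C(F)(F)F)cc1C(=O)Nc1ccc(S(=O)(=O)N2CCC[C@H]2C(=O)O)cc1`: > 300000 nM, a limit of the assay
Compound 2 `Cn1nc(C(F)(F)F)cc1C(=O)Nc1ccc(S(=O)(=O)N2CCNCC2)cc1`: 126000 nM

Going by the values given here, compound 2 holds the only actual number so far, since the entry for compound 1 is a limit. Compound 3 `Cn1nc(C(F)(F)F)cc1C(=O)Nc1ccc(S(=O)(=O)N2CCCCC2CO)cc1` differs from compound 2 in one group on a sulfonyl sulfur: 2-(hydroxymethyl)piperidin-1-yl in place of piperazin-1-yl on a sulfonyl sulfur. Among the compounds with values here, only one measured step bears on this place, an at least 2.3-fold lower number from compound 1 to compound 2 (0.37 log units; beyond the scatter), where piperazin-1-yl replaced 2-carboxypyrrolidin-1-yl. That step is a weak guide, as 2-(hydroxymethyl)piperidin-1-yl played no part in it. The group leaving and the group entering are both six-membered non-aromatic rings with no net charge. In this assay, no change beyond the scatter is therefore expected, and the estimated step, a 1.1-fold higher number from compound 2 to compound 3 (0.05 log units; within the scatter), is small. Compound 3 is estimated at 140000 nM, with an expected range of 60000 nM to 300000 nM.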

Compound 3, half-maximal cytotoxic concentration: 159000 nM
For compound 3 the middle estimate is 1.1-fold (0.06 log units) below the measured one; the range from low to high includes it.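

In this assay, 2-(hydroxymethyl)piperidin-1-yl in place of piperazin-1-yl on the sulfonyl sulfur gives a 1.3-fold higher number from compound 2 to compound 3 (0.10 log units; within the scatter), so this exchange, which brings in more heavy atoms and swaps a ring nitrogen for carbon, leaves no readable difference between the two compounds. The comparison with the carboxylic acid compound gives an at least 1.8-fold lower number from compound 1 to compound 3 (0.27 log units; that floor lies within the scatter), so even its floor does not clear the scatter, unlike the step to compound 2. Compound 1 has a limit rather than a number, so the true size of this step cannot be read: the limit of > 300000 nM in this assay, at which 1 of the 3 values shown sits.

The compounds shown leave open whether the carboxylic acid itself sets compound 1 apart, as neither a pyrrolidine ring without it nor a piperidine ring bearing it appears here. On these data alone, it also remains open how plain piperidin-1-yl or a longer hydroxyalkyl chain on the ring would read in this assay.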